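Cyclopropyl to cyclobutyl at the ether-bearing carbon

The compounds below may be only part of what the source reports. "The series", "measured", "known", "first", "only" and "open" are said of these compounds alone.

Measured so far:
compound 1, `CCCC(Oc1ccc(-n2cc(OC)cn2)cc1)c1ccc(C(=O)NCCC(=O)O)cc1`: 4400 nM
compound 2, `O=C(O)CCNC(=O)c1ccc(C(Oc2ccc(-n3cc(C(F)(F)F)cn3)cc2)C2CC2)cc1`: 1300 nM

Both were tested in an assay on cells for displacement of a labelled ligand from Glucagon receptor (Homo sapiens), in the presence of a further agent that is not named here; a lower number here means a stronger inhibitor, a higher number a weaker inhibitor: compound 1 gives 4400 nM and compound 2 gives 1300 nM. Compound 2 has the lower of the two numbers, and its gap to compound 1 lies beyond the scatter. Compound 3, `O=C(O)CCNC(=O)c1ccc(C(Oc2ccc(-n3cc(C(F)(F)F)cn3)cc2)C2CCC2)cc1`, differs from compound 2 in one place: cyclobutyl in place of cyclopropyl on a saturated chain carbon bound to an aromatic carbon and an oxygen on an aromatic ring. Within the data shown here, no measured pair shows this change, so its size is unknown from the data. The step of a 1.2-fold lower number from compound 2 to compound 3 (0.07 log units; within the scatter) is expected to stay within the scatter, with no clear direction. Compound 3 is therefore estimated at 1100 nM, within 400 nM to 3000 nM.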

Compound 3, inhibition constant: 700 nM
Estimate against measurement, compound 3: 1.6-fold (0.20 log units) above, and the stated range covers the measured number.
By their numbers in this assay, from the lowest: compounds 3 and 2 (each within the scatter of the next); then compound 1.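

Cyclobutyl in place of cyclopropyl on the saturated chain carbon bound to an aromatic carbon and an oxygen on an aromatic ring gives a 1.9-fold lower number from compound 2 to compound 3 (0.27 log units; within the scatter) in this assay as the reading for this change. This position therefore takes the four-membered ring as well as the three-membered ring, with no difference that can be told from the scatter. Nothing available accounts for this step.

Open, going by these compounds, is whether a larger ring such as cyclopentyl at this carbon keeps the same level. On these data alone, an amine or a hydroxyl on the cyclobutyl ring is equally open.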